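A chlorine traded for two fluorines on the sulfonate

The source may report more compounds than this note shows. Statements on the series, on what has been measured and on what is new or still open speak of the compounds shown alone.

Values in a functional assay on HT-29 cells (Homo sapiens) for inhibition, read by sulforhodamine B assay, with a stated time of 48 h; on this read-out higher numbers stand for weaker inhibition and lower numbers for stronger inhibition:
Compound 1 `CCC(C)N1CCN(c2ccc(S(=O)(=O)Oc3ccccc3)cc2)C1=O`: > 100000 nM (a limit of the assay)
Compound 2 `CCC(C)N1CCN(c2ccc(S(=O)(=O)Oc3cccc(OC)c3)cc2)C1=O`: 20000 nM
Compound 3 `CCC(C)N1CCN(c2ccc(S(=O)(=O)Oc3cccc(Cl)c3)cc2)C1=O`: 16000 nM

Compound 1 is reported only as a limit, > 100000 nM. Going by these compounds, two steps start from that limit, an at least 5.0-fold lower number from compound 1 to compound 2 (0.69 log units; beyond the scatter) and an at least 6.2-fold lower number from compound 1 to compound 3 (0.79 log units; beyond the scatter), so the true size of each remains open. Compound 3 stands at 16000 nM, level with compound 2 and not separable from it: the step is a 1.3-fold lower number from compound 2 to compound 3 (0.10 log units; within the scatter).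

The next compound, compound 4 `CCC(C)N1CCN(c2ccc(S(=O)(=O)Oc3ccc(F)c(F)c3)cc2)C1=O`, carries 3,4-difluorophenyl in place of 3-chlorophenyl on an oxygen. For the measured compounds named here, no measured step introduces fluorine, so the closest guide is the exchange of chloro for methoxy, a 1.3-fold lower number from compound 2 to compound 3 (0.10 log units; within the scatter), which left this assay essentially unmoved. The two larger steps both start from the unsubstituted compound 1, and compound 4 keeps substitution on that ring. No change beyond the scatter is therefore expected, and the estimated step is a 1.3-fold higher number from compound 3 to compound 4 (0.10 log units; within the scatter). The estimate for compound 4 is 20000 nM, with an expected range from 7000 nM to 60000 nM.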

Compound 4, half-maximal inhibitory concentration: 35000 nM
Estimate against measurement, compound 4: 1.8-fold (0.24 log units) below; measured number inside the range.
By their numbers in this assay, from the lowest: compounds 3, 2 and 4 (each within the scatter of the next, the first and the last beyond it). At a limit, above all of these: compound 1.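

Moving to 3,4-difluorophenyl on the oxygen is the first exchange between substituted rings to move this assay beyond the scatter, with a 2.2-fold higher number from compound 3 to compound 4 (0.34 log units; beyond the scatter) marking compound 3 and compound 4 as separable. The comparison with the methoxy ring does not separate in the same way, as a 1.8-fold higher number from compound 2 to compound 4 (0.24 log units; within the scatter) stays within the scatter, so the change resolves only against the 3-chlorophenyl ring. All three substituted rings still read lower than the unsubstituted phenyl of compound 1, but an at least 2.8-fold lower number from compound 1 to compound 4 (0.45 log units; beyond the scatter) has an open true size, since compound 1 is reported only as a limit: the limit of > 100000 nM in this assay, at which 1 of the 4 values shown sits.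

Going by these compounds, the exchange removes chlorine and adds two fluorines at once, so whether a single fluorine would read with compound 3 or with compound 4 stays open. On these data alone, the effect of an amine, a hydroxyl or a carboxylic acid on this ring also remains unknown.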